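Two Compounds at the Limit and a Third Expected There

This account rests on a few compounds, and the source may have more. Where it says the series, first, only, none or still open, it means among the compounds named here.

Compound 2 `Cc1cccc(-n2nncc2CN2C(=O)C3(C(C#N)=C(N)Oc4c(N)cc5nc6ccccc6nc5c43)c3ccccc32)c1` was tested in an ADME assay on L02 cells (Homo sapiens) for antiproliferative activity, read by MTT assay, with a stated time of 48 h; on this read-out lower numbers stand for stronger inhibition and higher numbers for weaker inhibition. In this assay compound 2 gives only a limit, > 50000 nM, and no number. Compound 1 `Cc1ccccc1-n1nncc1CN1C(=O)C2(C(C#N)=C(N)Oc3c2c2nc4ccccc4nc2c2ccccc32)c2ccccc21` was run in the same assay, where compound 1 likewise gives a limit, > 50000 nM. Where compound 2 stands is therefore fixed only by the limit of > 50000 nM in this assay, at which 2 of the 2 values shown sit, and no order between the two measured compounds can be read from these values, since each is a limit rather than a number.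

Compound 3 `N#CC1=C(N)Oc2c(N)cc3nc4ccccc4nc3c2C12C(=O)N(Cc1cnnn1-c1ccc(Cl)cc1)c1ccccc12` has not yet been measured in this assay. It differs from compound 2 in one place: 4-chlorophenyl in place of 3-methylphenyl on an aromatic nitrogen. Within the data shown here, with both measured compounds resting at the limit, there is no measured step to lean on. Compound 3 is therefore expected to show no step beyond the scatter, a step that the limit leaves unreadable from compound 2 to compound 3, and will most probably be reported as a limit again. Compound 3 is estimated at 60000 nM, with a range from 25000 nM to 200000 nM.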

Compound 3, half-maximal inhibitory concentration: > 50000 nM
Compound 3 ended at the assay's limit (the forecaster's own chance of this, stated with the estimate: 85%); the middle value does not contradict the limit.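

No step can be read from compound 2 to compound 3 in this assay, because each compound gives a limit and not a number: the limit of > 50000 nM in this assay, at which 3 of the 3 values shown sit.

The compounds shown leave open where the actual values of compound 1, compound 2 and compound 3 lie, and so whether 4-chlorophenyl in place of 3-methylphenyl makes any difference in this assay.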